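Replacing 4-hydroxyphenyl with tert-butyl in compound 1

The source may hold more compounds than are shown below. What is called first, only, known or untested is meant among the compounds shown, and "the series" means these compounds.

In a functional assay on MDA-MB-231 cells (Homo sapiens) for inhibition, read by sulforhodamine B assay, with a stated time of 48 h (a lower number here means a stronger inhibitor of growth, a higher number a weaker inhibitor of growth), compound 1 `Oc1ccc(-c2nc3ncccn3c2CN2CCCCC2)cc1` gives 7230 nM. Compound 2 `Cc1ccn2c(CN3CCCC3)c(-c3ccc(O)cc3)nc2n1` gives 1200 nM. Compound 1 therefore has the higher of the two numbers, making it the weaker growth inhibitor of this pair, and the gap lies beyond the usual scatter of repeated measurements.

Compound 3 `CC(C)(C)c1nc2ncccn2c1CN1CCCCC1` keeps the core of compound 1 and its (piperidin-1-yl)methyl group, but one substituent changes: tert-butyl in place of 4-hydroxyphenyl on an aromatic carbon. In words, tert-butyl stands in place of 4-hydroxyphenyl on an aromatic carbon, next to the ring atom that bears the (piperidin-1-yl)methyl group.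

For the measured compounds named here, no measured pair shows a change of this kind, so any forecast is uncertain. Going by the values given here, compound 1 at 7230 nM and compound 2 at 1200 nM both carry 4-hydroxyphenyl, and no tested compound lacks it. On that thin basis, weaker inhibition is expected in this assay, by a margin somewhat beyond the scatter. The estimated step is a 2.5-fold higher number from compound 1 to compound 3 (0.40 log units; beyond the scatter). For compound 3 the estimated value is 18000 nM, with an expected range of 5000 nM to 60000 nM.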

Compound 3, concentration for 50% growth inhibition: 1490 nM
For compound 3 the middle estimate is 12-fold (1.08 log units) above the measured one; the measured number lies below the stated range.
By their numbers in this assay, from the lowest: compounds 2 and 3 (each within the scatter of the next); then compound 1.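

In this assay, for the compounds shown here, putting tert-butyl in place of 4-hydroxyphenyl on this aromatic carbon gives a 4.9-fold lower number from compound 1 to compound 3 (0.69 log units; beyond the scatter) and so a stronger inhibitor of growth, the opposite of what might be assumed from the earlier compounds, which all carried 4-hydroxyphenyl. The group that leaves brings a six-membered aromatic ring, a hydrogen-bond donor and a hydrogen-bond acceptor, while tert-butyl has none of these, so within this pair none of the three is needed for growth inhibition at this level. No accompanying measurement tells which part of the change produces the step, and its cause stays unknown.

A plain phenyl group at this position would help separate the effect of the ring from that of its hydroxyl, while methyl or a cyclohexyl ring would test how much depends on the size and shape of the carbon group. On these data alone, it also remains open whether the same swap would give a similar step in compound 2, whose other substituents differ, since this result rests on a single pair of compounds.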